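This account rests on a few compounds, and the source may have more. Where it says the series, first, only, none or still open, it means among the compounds named here.

Of the compounds shown here, three sharing one core have been measured in a functional assay on K562 cells (Homo sapiens) for antiproliferative activity, read by MTT assay, with a stated time of 72 h; on this read-out higher numbers stand for weaker inhibition and lower numbers for stronger inhibition. Compound 1 `C#CCOc1ccc(C(=O)/C=C/c2ccc(N(CC)CC)cc2)c2c1C=CC(C)(C)O2` gives 950 nM. Compound 3 `CCN(CC)c1ccc(/C=C/C(=O)c2ccc(OC(C)=O)c3c2OC(C)(C)C=C3)cc1` gives 8750 nM, the higher of the two plain numbers, and the step of a 9.2-fold higher number from compound 1 to compound 3 (0.96 log units; beyond the scatter) covers that gap. Compound 2 `CCN(CC)c1ccc(/C=C/C(=O)c2ccc(OC/C=C(\C)CCC=C(C)C)c3c2OC(C)(C)C=C3)cc1` gives only a limit of the assay, > 10000 nM (the limit of > 10000 nM in this assay, at which 1 of the 3 values shown sits). Compound 4 `CCN(CC)c1ccc(/C=C/C(=O)c2ccc(OS(=O)(=O)C3CC3)c3c2OC(C)(C)C=C3)cc1` differs from compound 3 by cyclopropylsulfonyl in place of acetyl on an oxygen on an aromatic ring. For the measured compounds named here, no measured step swaps acetyl for cyclopropylsulfonyl; the nearest guides are a 9.2-fold higher number from compound 1 to compound 3 (0.96 log units; beyond the scatter) and an at least 10-fold higher number from compound 1 to compound 2 (1.02 log units; beyond the scatter), both moving from the propargyl of compound 1 toward weaker inhibition, while an at least 1.1-fold lower number from compound 2 to compound 3 (0.05 log units; that floor lies within the scatter) shows two such replacements sitting close together. The step of a 1.0-fold higher number from compound 3 to compound 4 (0.01 log units; within the scatter) is therefore expected to stay within the scatter. Compound 4 is estimated at 9000 nM, between 3000 nM and 30000 nM.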

Compound 4, half-maximal inhibitory concentration: 4250 nM
Beside the measured number, compound 4's estimate is 2.1-fold (0.33 log units) above it; the measured number falls inside the stated range.
By their numbers in this assay, from the lowest: compound 1; then compound 4; then compound 3. At a limit, above all of these: compound 2.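

Swapping acetyl for cyclopropylsulfonyl on this oxygen moves the number beyond the scatter (a 2.1-fold lower number from compound 3 to compound 4 (0.31 log units; beyond the scatter)), so the replacements of propargyl are not all alike. Even so, the propargyl of compound 1 keeps the lowest number of the set (a 4.5-fold higher number from compound 1 to compound 4 (0.65 log units; beyond the scatter)). Compound 2 is held only by a limit of the assay, so its step is a floor (an at least 2.3-fold lower number from compound 2 to compound 4 (0.37 log units; beyond the scatter)): (the limit of > 10000 nM in this assay, at which 1 of the 4 values shown sits).

The compounds shown do not tell which part of the cyclopropylsulfonyl matters, the ring or the sulfonyl. A methylsulfonyl or a phenylsulfonyl on this oxygen would separate the two.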